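Working notes on a chloro analogue in the cytotoxicity series

The compounds below may be only part of what the source reports. "The series", "measured", "known", "first", "only" and "open" are said of these compounds alone.

The series is anchored on compound 1 `C/C(=N\NC(=O)COc1cccc2ccccc12)c1ccccc1`. Among the compounds with values here, in an ADME assay on HEL cells (Homo sapiens) for cytotoxicity (a lower number here means that less compound is tolerated, a higher number that more compound is tolerated), compound 1 gives 20 ug/mL, which is the only full number in the set. Compound 2 `O=C(COc1cccc2ccccc12)N/N=C/c1cccc([N+](=O)[O-])c1` is the second measured member. For compound 2 this assay reports only a limit, >= 20 ug/mL, and not a number. That boundary the limit of >= 20 ug/mL in this assay, at which 1 of the 2 values shown sits, is where one of the two recorded values sits. Within the data shown here, no two measured compounds differ in a single place, so there is no measured step in this assay to lean on.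

Compound 3 `C/C(=N\NC(=O)COc1cccc2ccccc12)c1ccc(Cl)cc1` is the unmeasured member. It differs from compound 1 by chloro in place of hydrogen on an aromatic carbon. Among the measured compounds shown here, nothing among the measured compounds shows what chloro in place of hydrogen on an aromatic carbon does in this assay. The step of no change at the digits printed from compound 1 to compound 3 (within the scatter) is expected to stay within the scatter, with no direction favoured. Compound 3 is therefore expected to give 20 ug/mL in this assay, with a range from 7 ug/mL to 45 ug/mL, and a fair chance that only a limit is returned.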

Compound 3, minimum cytotoxic concentration: >= 4 ug/mL
Compound 3: only a limit was reported (the forecaster's own chance of this, stated with the estimate: 40%); the middle value does not contradict the limit.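

In this assay compound 3 returns only a limit, >= 4 ug/mL, and not a number. The step from compound 1 to compound 3 cannot be read, because the result for compound 3 stands at a limit: the limit of >= 4 ug/mL in this assay, at which 1 of the 3 values shown sits.

On these data alone, whether phenyl to 4-chlorophenyl shifts the read-out at all, and in which direction, stays open.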